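Swapping the benzyloxy substituent in a thiourea series

The source may report more compounds than this note shows. Statements on the series, on what has been measured and on what is new or still open speak of the compounds shown alone.

Measured compounds:
- compound 1 `Cc1ccc(NC(=S)NC(=O)c2ccc(OCc3cccc(Cl)c3)cc2)cc1-c1nc2ccccc2[nH]1`: 51300 nM
- compound 2 `Cc1ccc(NC(=S)NC(=O)c2ccc(OCc3ccc(C(F)(F)F)cc3)cc2)cc1-c1nc2ccccc2[nH]1`: 6500 nM
- compound 3 `Cc1ccc(NC(=S)NC(=O)c2ccc(OCc3cccc(C(F)(F)F)c3)cc2)cc1-c1nc2ccccc2[nH]1`: 5210 nM

In a functional assay on MGC-803 cells (Homo sapiens) for inhibition, read by MTT assay, with a stated time of 48 h (on this read-out lower numbers stand for stronger inhibition and higher numbers for weaker inhibition), compound 3 gives the lowest number of the three, though compound 2 sits within the scatter of it, while compound 1 lies well above both. Compound 4 `Cc1ccc(NC(=S)NC(=O)c2ccc(OCc3ccccc3F)cc2)cc1-c1nc2ccccc2[nH]1` is built from compound 3 by the change (2-fluorophenyl in place of 3-(trifluoromethyl)phenyl on a saturated chain carbon bound to an oxygen on an aromatic ring). Among the compounds with values here, the steps that bear on this are a 9.8-fold lower number from compound 1 to compound 3 (0.99 log units; beyond the scatter) and a 7.9-fold lower number from compound 1 to compound 2 (0.90 log units; beyond the scatter), where a chloro-bearing ring gave a clearly higher number than trifluoromethyl-bearing rings. Within the data shown here, a fluoro-bearing ring has no measured precedent here, so the expectation is uncertain: a move back toward compound 1 seems plausible, so a modest rise a 3.8-fold higher number from compound 3 to compound 4 (0.58 log units; beyond the scatter) is expected. For compound 4 in this assay the estimate is 20000 nM, with a range from 5000 nM to 80000 nM.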

Compound 4, half-maximal inhibitory concentration: 3070 nM
For compound 4 the middle estimate is 6.5-fold (0.81 log units) above the measured one; measured number outside the range, below it.
By their numbers in this assay, from the lowest: compounds 4, 3 and 2 (each within the scatter of the next, the first and the last beyond it); then compound 1.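

A 2-fluorophenyl ring at this place stays level with the 3-(trifluoromethyl)phenyl ring (a 1.7-fold lower number from compound 3 to compound 4 (0.23 log units; within the scatter)), so a trifluoromethyl group is not required to reach this range. The same ring also improves modestly on the 4-(trifluoromethyl)phenyl ring (a 2.1-fold lower number from compound 2 to compound 4 (0.33 log units; beyond the scatter)) and by far more on the 3-chlorophenyl ring (a 17-fold lower number from compound 1 to compound 4 (1.22 log units; beyond the scatter)), leaving compound 1 as the one clear outlier among these four. No measurement here explains these steps.

On these data alone, whether an unsubstituted phenyl ring, or a ring carrying a methoxy group or an amine, would group with compound 4 or with compound 1 remains open.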